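The source may hold more compounds than are shown below. What is called first, only, known or untested is meant among the compounds shown, and "the series" means these compounds.

Measured so far in a functional assay on MIA PaCa-2 cells (Homo sapiens) for antiproliferative activity, read by sulforhodamine B assay, with a stated time of 48 h; on this read-out higher numbers stand for weaker inhibition and lower numbers for stronger inhibition:
compound 1 `COc1cc(OC)c2sc(-c3ccc(N/C=C\C(=O)c4ccc(OC)c([N+](=O)[O-])c4)c(C)c3)nc2c1`, 13900 nM
compound 2 `COc1ccc(C(=O)/C=C\Nc2ccc(-c3nc4cc(OC)c(OC)c(OC)c4s3)cc2C)cc1[N+](=O)[O-]`, 23400 nM
compound 3 `COc1cc(OC)c2sc(-c3ccc(N/C=C\C(=O)c4ccc(OC)c([N+](=O)[O-])c4)cc3)nc2c1`, 2900 nM

On these three numbers compound 1 stands second highest; its nearest neighbour is compound 2, a 1.7-fold higher number from compound 1 to compound 2 (0.23 log units; within the scatter), and its furthest compound 3, a 4.8-fold lower number from compound 1 to compound 3 (0.68 log units; beyond the scatter). Compound 4 `COc1cc(OC)c2sc(-c3ccc(N/C=C\C(=O)c4ccc(OC)c(F)c4)c(C)c3)nc2c1` differs from compound 1 in one place: fluoro in place of nitro on an aromatic carbon. Within the data shown here, both measured steps alter other parts of the structure, so no measured step bears directly on this exchange, and the series gives no precedent for it. The step from compound 1 to compound 4 is therefore expected to be small, a 1.3-fold lower number from compound 1 to compound 4 (0.10 log units; within the scatter), with a wide range on either side. Compound 4 is estimated at 11000 nM, between 3000 nM and 40000 nM.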

Compound 4, half-maximal inhibitory concentration: 16300 nM
Estimate against measurement, compound 4: 1.5-fold (0.17 log units) below, and the stated range covers the measured number.
By their numbers in this assay, from the lowest: compound 3; then compounds 1, 4 and 2 (each within the scatter of the next).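

In this assay, fluoro in place of nitro ortho to a methoxy group gives a 1.2-fold higher number from compound 1 to compound 4 (0.07 log units; within the scatter), so on the core of compound 1 this position takes either group with no change beyond the scatter. The loss of two heavy atoms and both hydrogen-bond acceptors of the nitro group leaves this number effectively unmoved. No measurement at hand explains why the two groups read alike.

As far as these compounds go, whether an amine or a carboxylic acid at this position would read the same stays open. So does whether this exchange holds on compound 3.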